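Nitro in place of hydrogen on the aromatic ring of compound 2

This account rests on a few compounds, and the source may have more. Where it says the series, first, only, none or still open, it means among the compounds named here.

Compound 2 `C/C(=C\c1cc(-c2ccccc2)cs1)C(N)=O` gives > 50000 nM in a functional assay on T-24 cells (Homo sapiens) for cytotoxicity, read by CCK-8 assay, with a stated time of 24 h (a lower number here means a stronger inhibitor, a higher number a weaker inhibitor), and this is a limit of the assay rather than a number. Compound 1 `C/C(=C\c1cc(-c2ccccc2)co1)C(N)=O` gives > 50000 nM in this assay, also a limit. Compound 3 `C/C(=C\c1cc(-c2ccccc2C)cs1)C(N)=O` gives > 50000 nM in this assay, again a limit. The step that the two limits leave unreadable from compound 2 to compound 3 stays unreadable because of the limit of > 50000 nM in this assay, at which 3 of the 3 values shown sit. Compound 4 `C/C(=C\c1cc(-c2ccc([N+](=O)[O-])cc2)cs1)C(N)=O` differs from compound 2 by nitro in place of hydrogen on an aromatic carbon. Going by the values given here, no measured step tells how a nitro group changes potency here, and the single measured step cannot be read at all. Compound 4 is therefore expected to give 50000 nM in this assay, estimated between 10000 nM and 150000 nM. The step of a number no higher from compound 2 to compound 4 (the limit leaves the size open) is expected to be none beyond the scatter.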

Compound 4, half-maximal inhibitory concentration: > 50000 nM
Compound 4 was reported as a limit; the forecaster's own chance of this, stated with the estimate: 80%; the middle value sits exactly at the limit.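

No step can be read between compound 2 and compound 4, because both values are limits: the limit of > 50000 nM in this assay, at which 4 of the 4 values shown sit. The compounds shown leave open what potency any of them has in this assay, and how a nitro group changes it.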